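The source may hold more compounds than are shown below. What is called first, only, known or untested is meant among the compounds shown, and "the series" means these compounds.

Three measured compounds share one core and differ in a single group. In an ADME assay (liver) for metabolic stability, with Liver microsome (Homo sapiens) as the target, using microsomes and NADPH, with a stated time of 30 min, tested at 1 uM (on this read-out higher numbers stand for fast clearance and lower numbers for slow clearance), compound 1 `Nc1ccc(S(=O)(=O)N2CCN(c3ncc(C(O)(C(F)(F)F)C(F)(F)F)cc3Br)CC2)cn1`, which carries a bromo group, gives only a limit of the assay, < 14 mL.min-1.g-1. With a 1-ethyl-1H-pyrazol-4-yl group in that place, compound 2 `CCn1cc(-c2cc(C(O)(C(F)(F)F)C(F)(F)F)cnc2N2CCN(S(=O)(=O)c3ccc(N)nc3)CC2)cn1` gives 20 mL.min-1.g-1. With a 1-isopropyl-1H-pyrazol-4-yl group, compound 3 `CC(C)n1cc(-c2cc(C(O)(C(F)(F)F)C(F)(F)F)cnc2N2CCN(S(=O)(=O)c3ccc(N)nc3)CC2)cn1` gives 38 mL.min-1.g-1. Exchanging the bromo group gives an at least 2.7-fold higher number from compound 1 to compound 3 (0.43 log units; beyond the scatter), whereas the ethyl-bearing group gives an at least 1.4-fold higher number from compound 1 to compound 2 (0.15 log units; that floor lies within the scatter). Compound 3 thus stands apart from the limit of compound 1 but within the scatter of compound 2.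

The next compound, compound 4 `CC(C)(C)n1cc(-c2cc(C(O)(C(F)(F)F)C(F)(F)F)cnc2N2CCN(S(=O)(=O)c3ccc(N)nc3)CC2)cn1`, changes isopropyl to tert-butyl: methyl in place of hydrogen on a saturated chain carbon bound to an aromatic nitrogen and two saturated chain carbons. This places methyl in place of hydrogen on a saturated chain carbon bound to an aromatic nitrogen and two saturated chain carbons. Among the compounds with values here, the closest precedent is the ethyl-to-isopropyl change, which gives a 1.9-fold higher number from compound 2 to compound 3 (0.28 log units; within the scatter). That single step is weak guidance, so only a small move towards a higher number, within the scatter, seems reasonable. The expected size of the change is a 1.3-fold higher number from compound 3 to compound 4 (0.10 log units; within the scatter). For compound 4 the estimated clearance is 48 mL.min-1.g-1, with an expected range from 22 mL.min-1.g-1 to 105 mL.min-1.g-1.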

Compound 4, intrinsic clearance in microsomes: 86 mL.min-1.g-1
Compound 4: middle estimate off by 1.8-fold (0.25 log units), on the low side, within the range that was stated.
By their numbers in this assay, from the lowest: compounds 2 and 3 (each within the scatter of the next); then compound 4. At a limit, below all of these: compound 1.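

In this assay, a methyl in place of hydrogen on a saturated chain carbon bound to an aromatic nitrogen and two saturated chain carbons gives a 2.3-fold higher number from compound 3 to compound 4 (0.35 log units; beyond the scatter), so at this position one added methyl now produces a step beyond the scatter, which the step from ethyl to isopropyl did not. Tert-butyl in place of ethyl on the aromatic nitrogen gives a 4.3-fold higher number from compound 2 to compound 4 (0.63 log units; beyond the scatter), so compound 4 stands clear of both compound 2 and compound 3, even though those two lie within the scatter of each other. The step away from the bromo group, an at least 6.1-fold higher number from compound 1 to compound 4 (0.78 log units; beyond the scatter), is only a floor, because its starting value is a limit and not a number: the limit of < 14 mL.min-1.g-1 in this assay, at which 1 of the 4 values shown sits.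

The compounds shown leave open whether the higher number follows the added carbons alone or their branching, and a longer chain such as n-butyl on the same aromatic nitrogen would help to separate the two. They also leave open how a chain carrying oxygen, such as 2-methoxyethyl, or a carboxylic acid would read in this place.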